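Swapping a fluorobenzyl ether for a fluoropropyl ether

The source may hold more compounds than are shown below. What is called first, only, known or untested is meant among the compounds shown, and "the series" means these compounds.

Measured compounds:
compound 1, `c1ccc(COc2cccc(-c3cn(C4CN5CCC4CC5)nn3)c2)cc1`, gives 7.57 nM in an assay on HEK293 cells for displacement of a labelled ligand from Neuronal acetylcholine receptor; alpha3/beta4 (Homo sapiens), read by scintillation counting, with a stated time of 120 min; on this read-out higher numbers stand for weaker inhibition and lower numbers for stronger inhibition
compound 2, `FCCOc1cccc(-c2cn([C@@H]3CN4CCC3CC4)nn2)c1`, gives 11.8 nM in this assay
compound 3, `Fc1ccc(COc2cccc(-c3cn([C@@H]4CN5CCC4CC5)nn3)c2)cc1`, gives 7.17 nM in this assay

All three compounds share the same core and differ only in the group carried on the oxygen of the aromatic ring. For the measured compounds named here, compound 3 has the lowest number of the three, yet its gap to compound 1 and its gap to compound 2 both lie within the scatter, so no compound can be set apart from the others on these values.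

Compound 4, `FCCCOc1cccc(-c2cn([C@@H]3CN4CCC3CC4)nn2)c1`, is not yet measured. Its difference from compound 3 is 2-fluoroethyl in place of 4-fluorophenyl on a saturated chain carbon bound to an oxygen on an aromatic ring. Going by the values given here, the only measured step that speaks to this change is a 1.6-fold lower number from compound 2 to compound 3 (0.22 log units; within the scatter), which runs the other way: from a short fluorinated chain to a fluorinated aromatic ring. Going back from the ring to a chain in compound 4 is therefore expected to move the number, if at all, slightly upward, and the expected step of a 1.4-fold higher number from compound 3 to compound 4 (0.14 log units; within the scatter) stays within the scatter. The value of compound 4 in this assay is estimated at 10 nM, with a range from 5 nM to 20 nM.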

Compound 4, inhibition constant: 19.5 nM
The estimate for compound 4 lay 2.0-fold (0.29 log units) below the measured number; the measured number falls inside the stated range.
By their numbers in this assay, from the lowest: compounds 3, 1, 2 and 4 (each within the scatter of the next, the first and the last beyond it).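

In this assay, this change on the oxygen gives the first step beyond the scatter among these compounds, though a modest one: a 2.7-fold higher number from compound 3 to compound 4 (0.43 log units; beyond the scatter). The exchange of the 4-fluorobenzyl group for the 3-fluoropropyl group therefore has a readable effect here, whereas the two fluorinated chains cannot be told apart, with a 1.7-fold higher number from compound 2 to compound 4 (0.22 log units; within the scatter). No supporting measurement is available to explain the difference between compound 3 and compound 4.

The compounds shown leave open whether the fluorine on the chain plays any part in these numbers, a question that a plain propyl ether would address, and whether a longer chain, such as a 4-fluorobutyl group, would continue the upward reading seen with compound 4. Also open, on these data alone, is how a chain ending in an amine or a carboxylic acid would read at this place, so the tolerance of this position for groups other than fluorinated chains and fluorinated benzyl groups remains unknown.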